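Swapping cyclopropylcarbamoyl for 1,3,4-oxadiazol-2-yl on a shared core

The source may hold more compounds than are shown below. What is called first, only, known or untested is meant among the compounds shown, and "the series" means these compounds.

Compound 1 `O=C(NC1CC1)c1ccc(-c2nc3cccnc3n2C2CCCC2)cc1`: 115 nM
Compound 2 `Cn1ccc2cc(-c3nc4cccnc4n3C3CCCC3)ccc21`: 90 nM

In a functional assay on MDA-MB-231 cells (Homo sapiens) for cytotoxicity, read by MTT assay, with a stated time of 24 h (on this read-out lower numbers stand for stronger inhibition and higher numbers for weaker inhibition), compound 1 gives 115 nM and compound 2 gives 90 nM. These two values lie within the usual scatter of each other, so compound 1 cannot be ranked apart from compound 2.

Compound 3 `c1cnc2c(c1)nc(-c1ccc(-c3nnco3)cc1)n2C1CCCC1` has not yet been measured. It keeps the core of compound 1 but carries 1,3,4-oxadiazol-2-yl in place of cyclopropylcarbamoyl on an aromatic carbon, para to a large group (1,3,4-oxadiazol-2-yl in place of cyclopropylcarbamoyl on an aromatic carbon).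

Going by the values given here, no measured pair shows what this exchange does, so any expectation is tentative. In this assay, a modest move to a higher number is expected, and it may not exceed the scatter. The expected step is a 1.5-fold higher number from compound 1 to compound 3 (0.17 log units; within the scatter). For compound 3 the estimated value is 170 nM, with an expected range of 50 nM to 600 nM.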

Compound 3, half-maximal inhibitory concentration: 87 nM
Compound 3: middle estimate off by 2.0-fold (0.29 log units), on the high side; the range from low to high includes it.
By their numbers in this assay, from the lowest: compounds 3, 2 and 1 (each within the scatter of the next).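

In this assay, putting 1,3,4-oxadiazol-2-yl in place of cyclopropylcarbamoyl on this aromatic carbon gives a 1.3-fold lower number from compound 1 to compound 3 (0.12 log units; within the scatter) and so leaves the two compounds unranked. This first single-place comparison shows that the position accepts a five-membered aromatic ring in place of the amide-bearing group without a change beyond the scatter, even though the hydrogen-bond donor and the three-membered ring of carbon only are both gone. No measurement at hand accounts for this result.

One exchange cannot show whether the position responds at all to what is placed there, or whether any group would give a similar number. A carboxylic acid or a primary amine on the same carbon would test this, as would a longer chain on the amide nitrogen.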